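One aryl exchange on compound 2

A few compounds are considered here, and "the series" means these few. Any claim that something is new, unique, unknown or untested is made for them only; others in the source may bear on it.

Compound 1 `COc1ccc(NC(=O)Nc2cccc(-c3nc(-c4ccc(NC(=O)c5cccnc5)cc4Cl)no3)c2)cc1`: 3000 nM
Compound 2 `O=C(Nc1cccc(-c2nc(-c3ccc(NC(=O)c4cccnc4)cc3Cl)no2)c1)Nc1ccc(Cl)c(C(F)(F)F)c1`: 1900 nM

Among the compounds with values here, in a functional assay on MDA-MB-231 cells (Homo sapiens) for antiproliferative activity, read by MTT assay, with a stated time of 72 h (on this read-out lower numbers stand for stronger inhibition and higher numbers for weaker inhibition), compound 2 gives 1900 nM and stands level with compound 1 at 3000 nM on the two numbers so far. Within the data shown here, the only measured step is a 1.6-fold lower number from compound 1 to compound 2 (0.20 log units; within the scatter) and it does not separate them. Among the measured compounds shown here, compound 3 `CS(=O)(=O)Nc1ccc(NC(=O)Nc2cccc(-c3nc(-c4ccc(NC(=O)c5cccnc5)cc4Cl)no3)c2)cc1Cl` keeps the core of compound 2 but carries 3-chloro-4-(methanesulfonamido)phenyl in place of 4-chloro-3-(trifluoromethyl)phenyl on an amide-type nitrogen as its single change. For the measured compounds named here, the step measured at this same place is small, but it is one pair only, and no measured compound carries the entering group. The expected result is a 1.3-fold higher number from compound 2 to compound 3 (0.12 log units; within the scatter) and thus nothing beyond the scatter in either direction. The estimate for compound 3 is 2500 nM with 800 nM to 7000 nM as its expected range.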

Compound 3, half-maximal inhibitory concentration: 600 nM
Beside the measured number, compound 3's estimate is 4.2-fold (0.62 log units) above it; the measured number lies below the stated range.
By their numbers in this assay, from the lowest: compound 3; then compounds 2 and 1 (each within the scatter of the next).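

In this assay the aryl group on the amide-type nitrogen now proves able to move the number: 3-chloro-4-(methanesulfonamido)phenyl in place of 4-chloro-3-(trifluoromethyl)phenyl gives a 3.2-fold lower number from compound 2 to compound 3 (0.50 log units; beyond the scatter) and so does what the earlier step at this place did not. The same group in place of 4-methoxyphenyl gives a 5.0-fold lower number from compound 1 to compound 3 (0.70 log units; beyond the scatter) and sets compound 3 apart from both earlier compounds, by modest steps. Nothing measured here accounts for these steps.

With a single compound carrying the methanesulfonamido group, its share of the step cannot be separated from that of the chlorine on the same ring. Going by these compounds, whether an amine or a carboxylic acid in place of the methanesulfonamido group would keep the number at this level also stays open.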